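Adding 4-chlorophenyl to a compound at the assay limit

This account rests on a few compounds, and the source may have more. Where it says the series, first, only, none or still open, it means among the compounds named here.

In a functional assay on HCT-116 cells (Homo sapiens) for antiproliferative activity, read by MTT assay, with a stated time of 72 h (on this read-out lower numbers stand for stronger inhibition and higher numbers for weaker inhibition), compound 1 (`O=C1COc2ccc(-c3cccc(NS(=O)(=O)c4ccc(F)cc4)c3)cc2N1`) gives > 40000 nM, which is a limit and not a number. Compound 2 (`COc1ncc(-c2ccc3c(c2)N(c2ccc(F)cc2)C(=O)CO3)cc1NS(=O)(=O)c1ccc(F)cc1`) gives > 40000 nM, which is also a limit. Among the compounds with values here, compound 3 (`COc1ncc(-c2ccc3c(c2)N(c2ccccc2)C(=O)CO3)cc1NS(=O)(=O)c1ccc(F)cc1`) gives 18800 nM, the only true number. Compound 1 therefore stands at the limit of > 40000 nM in this assay, at which 2 of the 3 values shown sit, with no measured potency to serve as a starting point.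

Compound 4 (`O=C1COc2ccc(-c3cccc(NS(=O)(=O)c4ccc(F)cc4)c3)cc2N1c1ccc(Cl)cc1`) is compound 1 with 4-chlorophenyl in place of hydrogen on an amide-type nitrogen in a ring. Compound 2 and compound 3 also carry an aromatic ring on that nitrogen, but they differ from compound 4 elsewhere, so they offer only indirect guidance. Within the data shown here, the one measured step that bears on the change is an at least 2.1-fold lower number from compound 2 to compound 3 (0.32 log units; beyond the scatter). It concerns the group on that nitrogen, and it shows that a fluoro on that ring goes with the weaker reading. Compound 4 keeps a halogen there, so only a small shift towards lower numbers is expected, and another limit reading would be no surprise. The expected change is an at least 1.3-fold lower number from compound 1 to compound 4 (0.12 log units; that floor lies within the scatter). Compound 4 is estimated at 30000 nM, with an expected range from 10000 nM to 40000 nM.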

Compound 4, half-maximal inhibitory concentration: 23900 nM
Compound 4: the middle estimate sits 1.3-fold (0.10 log units) above what was measured; the measured number falls inside the stated range.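

Within the data shown here, on the amide-type nitrogen in a ring, 4-chlorophenyl in place of hydrogen is the one change here read directly on the core of compound 1, and in this assay it gives an at least 1.6-fold lower number from compound 1 to compound 4 (0.22 log units; that floor lies within the scatter). The position thus carries this aromatic ring and returns a true number rather than a limit, although the floor of the step alone does not establish a real gain in potency. The true size of the step stays unknown, because the reading for compound 1 is a limit and not a number: the limit of > 40000 nM in this assay, at which 2 of the 4 values shown sit.

On these data alone, whether the effect belongs to the chlorine or to the phenyl ring itself remains open on this core, as does the outcome with a methyl, a benzyl or a 4-methoxyphenyl on the same nitrogen. Also open, as far as these compounds go, is whether a basic amine or a carboxylic acid carried on that ring would move the antiproliferative reading well away from that of compound 4, which at 23900 nM remains a weak value on this read-out.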